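The source may report more compounds than this note shows. Statements on the series, on what has been measured and on what is new or still open speak of the compounds shown alone.

Compound 1, `CC1=C(/C=C/C(=O)/C=C/c2ccccc2)C(C)(C)CCC1`, in a functional assay on IMR-32 cells (Homo sapiens) for cytotoxicity, read by sulforhodamine B assay, with a stated time of 48 h; a lower number here means a stronger inhibitor, a higher number a weaker inhibitor: 20400 nM
Compound 2, `CC1=C(/C=C/C(=O)/C=C/c2ccc(F)cc2)C(C)(C)CCC1`, in this assay: 7400 nM
Compound 3, `CC1=C(/C=C/C(=O)/C=C/c2ccccc2Br)C(C)(C)CCC1`, in this assay: 16300 nM

Among these three, compound 3 sits second highest: its number is within the scatter of compound 1 but is a 2.2-fold higher number from compound 2 to compound 3 (0.34 log units; beyond the scatter). Compound 4, `CC1=C(/C=C/C(=O)/C=C/c2ccccc2F)C(C)(C)CCC1`, differs from compound 3 by one swap: fluoro in place of bromo on an aromatic carbon, on an aromatic carbon of a six-membered aromatic ring of carbon only, ortho to a large group. Going by the values given here, two measured steps bear on this. Putting a fluoro onto the plain ring gave a 2.8-fold lower number from compound 1 to compound 2 (0.44 log units; beyond the scatter), a modest gain, while putting a bromo onto the plain ring gave a 1.3-fold lower number from compound 1 to compound 3 (0.10 log units; within the scatter), nothing beyond the scatter. The fluoro gain was seen at a different place on the ring, so it cannot simply be carried over, but it suggests that fluoro is the more favourable of the two halogens here. For compound 4 a small step downward in this assay is therefore expected, around the edge of the scatter: a 1.4-fold lower number from compound 3 to compound 4 (0.13 log units; within the scatter). The estimate for compound 4 is 12000 nM, with a range from 6000 nM to 24000 nM.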

Compound 4, half-maximal inhibitory concentration: 15600 nM
Compound 4: middle estimate off by 1.3-fold (0.11 log units), on the low side; the range from low to high includes it.
By their numbers in this assay, from the lowest: compound 2; then compounds 4, 3 and 1 (each within the scatter of the next).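

In this assay, swapping bromo for fluoro at this position makes no difference that can be told apart: a 1.0-fold lower number from compound 3 to compound 4 (0.02 log units; within the scatter). Adding fluoro here to the plain ring is just as indistinct, with a 1.3-fold lower number from compound 1 to compound 4 (0.12 log units; within the scatter), whereas the fluoro of compound 2 sits at a different place on the ring and that change alone gives a 2.1-fold higher number from compound 2 to compound 4 (0.32 log units; beyond the scatter), so the place of the fluoro counts for more here than which of the two halogens is at this position. No measurement here explains why the place matters.

Still open, as far as these compounds go, is whether a group other than a halogen, such as a methoxy or an amine, would shift the number at this position. From the compounds shown here alone, it is also open whether a bromo at the place the fluoro holds in compound 2 would match compound 2.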